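Methoxy in Place of Ethyl: A Clearance Estimate

The source may hold more compounds than are shown below. What is called first, only, known or untested is meant among the compounds shown, and "the series" means these compounds.

Three related compounds have been measured in an ADME assay on microsomes from liver (Homo sapiens) for metabolic stability; a higher number here means faster removal of the compound, a lower number slower removal. There, compound 1 (`CC(C)n1cnc2c(-c3ccc(F)c(Oc4ccc(C#N)cn4)c3)cnnc21`) gives 38 mL.min-1.g-1 while compound 2 (`CCn1cnc2c(-c3ccc(F)c(-c4cc(C#N)ccc4OC)c3)cnnc21`) gives 66 mL.min-1.g-1 and compound 3 (`CCc1cnn2c(-c3ccc(F)c(-c4ccc(S(=O)(=O)CC)cc4)c3)cnnc12`) gives 33 mL.min-1.g-1 in the same test. These three numbers lie within the usual scatter of one another, so compound 3 cannot be told apart from the other two, even though its number is the smallest written down.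

Compound 4 (`CCS(=O)(=O)c1ccc(-c2cc(-c3cnnc4c(OC)cnn34)ccc2F)cc1`) carries methoxy in place of ethyl on an aromatic carbon of compound 3 (methoxy in place of ethyl on an aromatic carbon). For the measured compounds named here, no measured pair of compounds shows this exchange on its own, so the data offer no direct guide to its size or direction. The expected result is a 1.1-fold lower number from compound 3 to compound 4 (0.04 log units; within the scatter) and this estimated step is not expected to exceed the scatter, with no firm direction. For compound 4 the estimated clearance is 30 mL.min-1.g-1 with an expected range from 14 mL.min-1.g-1 to 60 mL.min-1.g-1 in this assay.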

Compound 4, intrinsic clearance in microsomes in the Homo sapiens assay: < 8 mL.min-1.g-1
Compound 4 gave a limit, no number; the forecaster's own chance of this, stated with the estimate: 3%; at least 3.7-fold (0.57 log units) between middle value and limit.
By their numbers in the Homo sapiens assay, from the lowest: compounds 3, 1 and 2 (each within the scatter of the next). At a limit, below all of these: compound 4.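

In the Homo sapiens assay, methoxy in place of ethyl at this position gives an at least 4.1-fold lower number from compound 3 to compound 4 (0.61 log units; beyond the scatter), showing that this single exchange on an aromatic carbon can move clearance beyond the scatter, something the three earlier compounds, all within the scatter of one another, could not show. From the compounds shown here alone, the entry for compound 4 is a limit and not a number, and the full size of the step stays unknown: the limit of < 8 mL.min-1.g-1 in the Homo sapiens assay, at which 1 of the 4 values shown sits. In a physicochemical assay for lipophilicity (a lower number here means a more polar compound, a higher number a more lipophilic compound), compound 3 gives 3.5 and compound 4 gives 2.8. The same exchange comes with lower lipophilicity, which may contribute to the slower removal, though a single pair cannot settle that: the measured distribution coefficient of compound 3, 3.5, and of compound 4, 2.8, a number 0.70 log units lower (beyond the scatter).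

Going by these compounds, whether an amine or a longer ether such as ethoxy on this carbon would give a similar step remains open. On these data alone, it is also open whether methoxy would act the same way on the core of compound 1.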